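A few compounds are considered here, and "the series" means these few. Any claim that something is new, unique, unknown or untested is made for them only; others in the source may bear on it.

Of the compounds shown here, three built on one shared core have been measured in an assay on cells for inhibition of histone deacetylase 8 (Homo sapiens), read by fluorescence, with a stated time of 30 min; a lower number here means a stronger inhibitor, a higher number a weaker inhibitor. Compound 1 `Cc1ccc(C2CC(c3ccccc3)=NN2C(=O)COc2ccc(/C=C3/SC(=O)NC3=O)cc2)cc1` gives 31000 nM, compound 2 `O=C1NC(=O)/C(=C\c2ccc(OCC(=O)N3N=C(c4ccccc4)CC3c3ccc(Cl)c(Cl)c3)cc2)S1` gives 10000 nM, and compound 3 `O=C1NC(=O)/C(=C\c2ccc(OCC(=O)N3N=C(c4ccccc4)CC3c3ccc(Br)cc3)cc2)S1` gives 35000 nM. Compound 2 thus has the lowest number of the three, and because both a 3.1-fold lower number from compound 1 to compound 2 (0.49 log units; beyond the scatter) and a 3.5-fold higher number from compound 2 to compound 3 (0.54 log units; beyond the scatter) are beyond the scatter, it stands as the strongest inhibitor in this small set. Compound 4 `O=C1NC(=O)/C(=C\c2ccc(OCC(=O)N3N=C(c4ccc(F)cc4)CC3c3ccc(Cl)c(Cl)c3)cc2)S1` differs from compound 2 by fluoro in place of hydrogen on an aromatic carbon. For the measured compounds named here, no measured step touches this ring: the two steps just named exchange the group on the saturated ring carbon, and the only change on an aromatic carbon, a 1.1-fold higher number from compound 1 to compound 3 (0.05 log units; within the scatter), lies within the scatter and concerns the other aromatic ring. There is therefore no direct guide, and the nearest comparison suggests no movement beyond the scatter. Compound 4 is expected to give about 10000 nM, with a likely range from 4000 nM to 25000 nM, meaning an estimated step of no change at the digits printed from compound 2 to compound 4 (within the scatter).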

Compound 4, half-maximal inhibitory concentration: 25000 nM
Compound 4: middle estimate off by 2.5-fold (0.40 log units), on the low side, and the stated range covers the measured number.
By their numbers in this assay, from the lowest: compound 2; then compounds 4, 1 and 3 (each within the scatter of the next).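

The aromatic carbon that now carries fluoro, on a six-membered aromatic ring and para to a large group, was untouched by any earlier step, and this result shows that a change there can move the number: in this assay there is a 2.5-fold higher number from compound 2 to compound 4 (0.40 log units; beyond the scatter). Replacing a single hydrogen with fluoro, one heavy atom, is enough here to give a weaker inhibitor by more than the scatter. Compound 2 remains the strongest inhibitor of the set, but no available data explain this loss.

From the compounds shown here alone, whether the same step would appear with 4-methylphenyl or 4-bromophenyl on the saturated ring carbon remains open. Also open, going by these compounds, is what chloro, methoxy or an amine would do at this aromatic carbon, which would show whether the loss is specific to fluoro or follows other replacements of the hydrogen.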